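A Ring Nitrogen Added to Compound 2

A few compounds are considered here, and "the series" means these few. Any claim that something is new, unique, unknown or untested is made for them only; others in the source may bear on it.

Of the compounds shown here, two sharing a urea core have been measured. Compound 1 `Cc1cccc2c1cnn2-c1ccc(NC(=O)Nc2ccc(Cl)c(C(F)(F)F)c2)cc1` gives 2500 nM in a functional assay on NCI-H460 cells (Homo sapiens) for cytotoxicity, read by MTT assay, with a stated time of 72 h; a lower number here means a stronger inhibitor, a higher number a weaker inhibitor. For the measured compounds named here, compound 2 `O=C(Nc1ccc(-n2ncc3ccccc32)cc1)Nc1ccc(Cl)c(C(F)(F)F)c1` gives 5500 nM in this assay, the highest of the two numbers, and the only measured step, a 2.2-fold higher number from compound 1 to compound 2 (0.34 log units; beyond the scatter), separates them. Compound 3 `O=C(Nc1ccc(-n2ncc3cnccc32)cc1)Nc1ccc(Cl)c(C(F)(F)F)c1` has not yet been measured. It differs from compound 2 in one place: a group of 9 heavy atoms (6 carbon, 3 nitrogen; one five-membered aromatic ring with 2 hetero atoms, one six-membered aromatic ring with 1 hetero atom) in place of a group of 9 heavy atoms (7 carbon, 2 nitrogen; one five-membered aromatic ring with 2 hetero atoms, one six-membered aromatic ring of carbon only), on an aromatic carbon. Going by the values given here, no measured step exchanges one ring system for another; the single known step concerns the loss of a methyl group, which is a different kind of change and offers no direct guide here. With nothing firmer to lean on, the expected step is no change at the digits printed from compound 2 to compound 3 (within the scatter), meaning no change beyond the scatter in either direction. Compound 3 is therefore estimated at 5500 nM in this assay, with a range from 2000 nM to 15000 nM that leaves room for a genuine shift either way once the number is in hand.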

Compound 3, half-maximal inhibitory concentration: 1400 nM
Estimate against measurement, compound 3: 3.9-fold (0.59 log units) above, outside the stated range (below it).
By their numbers in this assay, from the lowest: compounds 3 and 1 (each within the scatter of the next); then compound 2.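

In this assay, this position turns out to respond to a change in the ring atoms themselves, not only to a methyl group carried on the ring: exchanging the 1H-indazol-1-yl group for its counterpart with a nitrogen in the six-membered ring, at the same count of heavy atoms, gives a 3.9-fold lower number from compound 2 to compound 3 (0.59 log units; beyond the scatter). Two different edits of this group now stand apart from compound 2, and the data do not separate them from each other, with a 1.8-fold lower number from compound 1 to compound 3 (0.25 log units; within the scatter). Nothing measured here explains why one added ring nitrogen shifts the number in this cell assay.

The compounds shown leave open whether the nitrogen matters for where it sits in the six-membered ring or simply for being there, and whether the methyl group and the ring nitrogen together in one compound would lower the number further. On these data alone, it also remains open how a methoxy group, an amine or a fluorine on that same ring would compare, and whether any of these changes could bring the number well beyond the narrow range seen so far.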